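The source may hold more compounds than are shown below. What is called first, only, known or untested is meant among the compounds shown, and "the series" means these compounds.

- Compound 1 `Cn1cc(C2=C(c3nn(CCCn4cncn4)c4ncccc34)C(=O)N(c3ccccc3)C2=O)c2ccccc21`: > 100000 nM, a limit of the assay
- Compound 2 `Cn1cc(C2=C(c3nn(CCCN4CCCCC4)c4ncccc34)C(=O)N(c3ccccc3)C2=O)c2ccccc21`: 12300 nM
- Compound 3 `Cn1cc(C2=C(c3nn(CCCN4CCCCC4)c4ncccc34)C(=O)N(c3cccc4ccccc34)C2=O)c2ccccc21`: 1830 nM

In a functional assay on ECa-109 cells (Homo sapiens) for antiproliferative activity, read by MTT assay, with a stated time of 48 h (on this read-out higher numbers stand for weaker inhibition and lower numbers for stronger inhibition), compound 2 holds the higher of the two true numbers. The other lies lower, as a 6.7-fold lower number from compound 2 to compound 3 (0.83 log units; beyond the scatter) shows, but that change is on an amide-type nitrogen in a ring and says little here. The value of compound 1 is a limit and not a number.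

Compound 4 `Cn1cc(C2=C(c3nn(CCCn4ccnc4)c4ncccc34)C(=O)N(c3ccccc3)C2=O)c2ccccc21` carries 1H-imidazol-1-yl in place of piperidin-1-yl, on a saturated chain carbon, three bonds along the chain from an aromatic nitrogen: 1H-imidazol-1-yl in place of piperidin-1-yl on a saturated chain carbon, three bonds along the chain from an aromatic nitrogen. The step that bears on this is an at least 8.1-fold lower number from compound 1 to compound 2 (0.91 log units; beyond the scatter), where piperidin-1-yl replaced 1H-1,2,4-triazol-1-yl at that same place. The new change removes piperidin-1-yl again, so a move to a higher number in this assay, beyond the scatter, is expected, though this rests on one pair only. The expected change is a 3.3-fold higher number from compound 2 to compound 4 (0.51 log units; beyond the scatter). Compound 4 is estimated at 40000 nM, with an expected range from 13000 nM to 100000 nM.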

Compound 4, half-maximal inhibitory concentration: 1440 nM
Beside the measured number, compound 4's estimate is 28-fold (1.44 log units) above it, outside the stated range (below it).
By their numbers in this assay, from the lowest: compounds 4 and 3 (each within the scatter of the next); then compound 2. At a limit, above all of these: compound 1.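

In this assay, the place on a saturated chain carbon, three bonds along the chain from an aromatic nitrogen, does not depend on piperidin-1-yl: 1H-imidazol-1-yl in its stead gives an 8.5-fold lower number from compound 2 to compound 4 (0.93 log units; beyond the scatter) at this place. A six-membered non-aromatic ring is therefore not needed here, and the choice between 1H-imidazol-1-yl and 1H-1,2,4-triazol-1-yl also counts, with an at least 69-fold lower number from compound 1 to compound 4 (1.84 log units; beyond the scatter) on the same chain. The value of compound 1 in that comparison is a limit: the limit of > 100000 nM in this assay, at which 1 of the 4 values shown sits.

The compounds shown leave open whether naphthalen-1-yl on the amide-type nitrogen would lower the number of compound 4 as it did for compound 2. From the compounds shown here alone, how a morpholin-4-yl group, a dimethylamino group or a longer chain would read at this place also stays open.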